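A Nitro Ester on the Aromatic Core

The source may report more compounds than this note shows. Statements on the series, on what has been measured and on what is new or still open speak of the compounds shown alone.

Two esters have been measured in a functional assay on K562 cells (Homo sapiens) for antiproliferative activity, read by sulforhodamine B assay, with a stated time of 48 h, tested at 50 uM; a higher number here means more inhibition at the concentration tested (going by the name of the read-out), a lower number less inhibition. Compound 1 `CC1=CC[C@H](C(C)C)c2cc(C)c(OC(=O)c3ccc([N+](=O)[O-])cc3)cc21` gives 89% there. For the measured compounds named here, compound 2 `Cc1cc2c(C(C)C)ccc(C)c2cc1OC(=O)c1ccc(C(F)(F)F)cc1`, built on a different core, gives 45.1% in this assay, the lower of the two numbers and beyond the scatter from compound 1; no single-point step links these two. Compound 3 `Cc1cc2c(C(C)C)ccc(C)c2cc1OC(=O)c1ccc([N+](=O)[O-])cc1` keeps the core of compound 2 with one change: nitro in place of trifluoromethyl on an aromatic carbon. Compound 1, with 89%, carries the same nitro ester. An upward step a number 19.9 percentage points higher from compound 2 to compound 3 (beyond the scatter) is therefore expected. Compound 3 is estimated at 65%, within 40% to 88%.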

Compound 3, a percentage reported as inhibition, at one concentration (the size of the read-out at that concentration, not a potency): 100%
Compound 3: middle estimate off by 35 percentage points, on the low side; the whole stated range lies below it.
By their numbers in this assay, from the lowest: compound 2; then compound 1; then compound 3.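

In this assay nitro in place of trifluoromethyl on an aromatic carbon, para to a large group, gives a number 54.9 percentage points higher from compound 2 to compound 3 (beyond the scatter) and so shows that the number on this core depends strongly on which of these two groups sits there. The earlier compounds shown here differ in their cores and could not show this. No measurement at hand explains the step.

As far as these compounds go, whether an amine, a nitrile or a carboxylic acid in this place would give a number like that of compound 3 stays open. So does whether the same exchange on the core of compound 1 would give a step of similar size.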